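Swapping the Aryl Group on the Ring Nitrogen

A few compounds are considered here, and "the series" means these few. Any claim that something is new, unique, unknown or untested is made for them only; others in the source may bear on it.

Compound 1 is `Cc1cccc(N2C(=O)/C(=C/c3ccc(OCc4ccc(C(=O)O)cc4)cc3)SC2=S)c1`. In an assay on isolated protein for inhibition of Apoptosis regulator Bcl-2 (Homo sapiens), read by fluorescence polarization (a lower number here means a stronger inhibitor, a higher number a weaker inhibitor), compound 1 gives > 10000 nM, which is a limit of the assay rather than a number.
Compound 2 is `CC(=O)c1ccc(N2C(=O)/C(=C/c3ccc(OCc4ccc(C(=O)O)cc4)cc3)SC2=S)cc1`. In this assay compound 2 gives > 10000 nM, again a limit of the assay.

Compound 2 therefore stands at the edge of what this assay can report, and it is not alone there: the limit of > 10000 nM in this assay, at which 2 of the 2 values shown sit. Going by the values given here, the one change measured so far, a step that the two limits leave unreadable from compound 1 to compound 2, cannot be read in size or direction, since both ends of it are limits.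

Compound 3 is `O=C(O)c1ccc(COc2ccc(/C=C3\SC(=S)N(c4cccc(C(F)(F)F)c4)C3=O)cc2)cc1`. It differs from compound 2 in one place: 3-(trifluoromethyl)phenyl in place of 4-acetylphenyl on an amide-type nitrogen in a ring. Among the compounds with values here, the only measured step that touches this position is the unreadable one from compound 1 to compound 2, so no direction can be taken from the numbers, and the most that can be said is that two different aryl groups at this position both left the compound beyond the limit.

Compound 3 is therefore expected to sit at or beyond that limit as well, with an estimated step that the limit leaves unreadable from compound 2 to compound 3. Compound 3 is estimated at 15000 nM in this assay. For compound 3 the range is expected to run from 4000 nM to 60000 nM.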

Compound 3, inhibition constant: > 10000 nM
Compound 3 ended at the assay's limit; the forecaster's own chance of this, stated with the estimate: 80%; the middle value does not contradict the limit.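

No step among compound 1, compound 2 and compound 3 can be read in size or direction, because all three results are limits of the assay and not numbers: the limit of > 10000 nM in this assay, at which 3 of the 3 values shown sit.

The compounds shown leave open how far beyond that limit each one lies, and whether any aryl group on the amide-type nitrogen in the ring can bring a compound within the measurable range of this assay.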